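The compounds below may be only part of what the source reports. "The series", "measured", "known", "first", "only" and "open" are said of these compounds alone.

Values in a functional assay on HL-60 cells (Homo sapiens) for inhibition, read by MTT assay, with a stated time of 72 h (on this read-out lower numbers stand for stronger inhibition and higher numbers for weaker inhibition), two compounds so far:
- compound 1 `Cc1nc(-c2ccccc2F)c(C(=O)N2CCN(c3cc(Cl)ccc3C)CC2)o1` gives 229 nM
- compound 2 `Cc1nc(-c2ccccc2)c(C(=O)N2CCN(c3cccc(Cl)c3Cl)CC2)o1` gives 133 nM

Compound 1 at 229 nM and compound 2 at 133 nM lie within the scatter of each other, so these two numbers do not separate the pair. Within the data shown here, compound 1 therefore stands level with the only other measured compound. Among the measured compounds shown here, the two differ in more than one place, and no measured step isolates a single change, so the series offers no direct reading for any one group.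

Compound 3 `Cc1nc(-c2ccccc2F)c(C(=O)N2CCN(c3cc(Cl)cc(Cl)c3)CC2)o1` keeps the core of compound 1 and carries 3,5-dichlorophenyl in place of 5-chloro-2-methylphenyl on an amine nitrogen in a ring. The group entering and the group leaving are the same size in heavy atoms. With compound 2 at 133 nM as the only other reference, no change beyond the scatter is expected in this assay and no firm direction can be assigned. The expected step is a 1.3-fold lower number from compound 1 to compound 3 (0.10 log units; within the scatter), which stays an estimate with a wide margin. For compound 3 the estimated value is 180 nM, with an expected range from 60 nM to 540 nM in this read-out.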

Compound 3, half-maximal inhibitory concentration: 60.2 nM
Beside the measured number, compound 3's estimate is 3.0-fold (0.48 log units) above it; the measured number falls inside the stated range.
By their numbers in this assay, from the lowest: compound 3; then compounds 2 and 1 (each within the scatter of the next).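

In this assay, among these compounds, the group on the amine nitrogen in the six-membered ring is the first place where a single change gives a step beyond the scatter: 3,5-dichlorophenyl in place of 5-chloro-2-methylphenyl gives a 3.8-fold lower number from compound 1 to compound 3 (0.58 log units; beyond the scatter) on the core of compound 1. The two groups match in heavy atoms, aromatic ring and hydrogen-bond counts, so the step appears with no change in any of these counts; the only counted difference is one carbon leaving and one chlorine entering. No measurement shown here bears on what lies behind this step.

The pair cannot separate the loss of the methyl from the gain of the second chlorine, or either of these from the change in substitution pattern; a plain phenyl, a 3,5-dimethylphenyl or a phenyl bearing a single chlorine on that nitrogen would begin to divide these readings. Going by these compounds, whether the same step holds on another core also remains open, as does the effect of a non-aromatic group at this nitrogen, such as cyclohexyl.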